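The source may report more compounds than this note shows. Statements on the series, on what has been measured and on what is new or still open speak of the compounds shown alone.

Measured compounds:
Compound 1 `CC(=O)SCC(=O)c1ccc(NS(=O)(=O)c2ccc(OCCc3ccccn3)cc2)nc1`: 9600 nM
Compound 2 `CC(=O)SCC(=O)c1ccc(NS(=O)(=O)c2ccc(OCCCN3CCCC3)cc2)nc1`: 400 nM
Compound 3 `COCCCOc1ccc(S(=O)(=O)Nc2ccc(C(=O)CSC(C)=O)cn2)cc1`: 29000 nM

In a functional assay on U226 cells (Homo sapiens) for cytotoxicity (a higher number here means that more compound is needed for the effect, a lower number that less compound is needed), compound 1 stands second highest of the three numbers. Its nearest neighbour is compound 3, reached by a 3.0-fold higher number from compound 1 to compound 3 (0.48 log units; beyond the scatter), and its furthest is compound 2, reached by a 24-fold lower number from compound 1 to compound 2 (1.38 log units; beyond the scatter). Between those two the gap is a 73-fold higher number from compound 2 to compound 3 (1.86 log units; beyond the scatter).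

Compound 4 `CC(=O)SCC(=O)c1ccc(NS(=O)(=O)c2ccc(OCCCCN(C)C)cc2)nc1` differs from compound 1 in one place: 2-(dimethylamino)ethyl in place of pyridin-2-yl on a saturated chain carbon, two bonds along the chain from an oxygen on an aromatic ring. Two of the measured steps bear on this change, since both replace the same pyridin-2-yl group in compound 1 at the same place. The step to compound 2, which brings in (pyrrolidin-1-yl)methyl, gave a large lower number, while the step to compound 3, which brings in methoxymethyl, gave a modest higher number. The entering 2-(dimethylamino)ethyl group of compound 4 resembles the change toward compound 2 rather than toward compound 3 in that a nitrogen enters the chain, so a large step toward a lower number in this assay is expected, though perhaps not quite as far as compound 2 reached.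

Compound 4 is therefore estimated to show 700 nM in this assay, with a range from 200 nM to 2500 nM. That estimate corresponds to an expected step of a 14-fold lower number from compound 1 to compound 4 (1.14 log units; beyond the scatter).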

Compound 4, half-maximal effective concentration: 120 nM
Beside the measured number, compound 4's estimate is 5.8-fold (0.77 log units) above it, and the stated range ends above it.
By their numbers in this assay, from the lowest: compound 4; then compound 2; then compound 1; then compound 3.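

In this assay, 2-(dimethylamino)ethyl in place of pyridin-2-yl gives an 80-fold lower number from compound 1 to compound 4 (1.90 log units; beyond the scatter) and so takes this position lower than compound 2 had reached, while (dimethylamino)methyl in place of methoxy gives a 240-fold lower number from compound 3 to compound 4 (2.38 log units; beyond the scatter) as the widest step in the set. A second chain ending in an amine now stands with compound 2 at the low end of the series, whereas compound 1, whose pyridin-2-yl also holds a nitrogen, stays at the high end with compound 3, so a nitrogen in the entering group does not by itself go with a low number. The change from pyrrolidin-1-yl to (dimethylamino)methyl gives a 3.3-fold lower number from compound 2 to compound 4 (0.52 log units; beyond the scatter) beyond the scatter, but it alters the amine and the chain together, so the two cannot be told apart. No evidence is available to explain these differences.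

As far as these compounds go, how a dimethylamino group would behave on the shorter chain of compound 2, or a pyrrolidin-1-yl group on the 4-(dimethylamino)butoxy chain length of compound 4, remains open. So does the effect of a piperidine ring or a carboxylic acid at the end of the chain.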